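The compounds below may be only part of what the source reports. "The series", "measured", "known", "first", "only" and "open" are said of these compounds alone.

Working notes on the series. Compound 1 `O=C(Nc1cnn(-c2ccccc2)c1)c1cccc(NS(=O)(=O)c2ccccc2)c1` is the reference point of the set; in a functional assay on HepG2 cells (Homo sapiens) for inhibition, read by MTT assay, with a stated time of 48 h (a higher number here means a weaker inhibitor, a lower number a stronger inhibitor), compound 1 gives 10100 nM. Compound 2 `Cc1ccc(-n2cc(NC(=O)c3cccc(NS(=O)(=O)c4ccccc4)c3)cn2)cc1` differs from it by methyl in place of hydrogen on an aromatic carbon, and in this assay compound 2 gives 6050 nM, a step of a 1.7-fold lower number from compound 1 to compound 2 (0.22 log units; within the scatter). Compound 3 `O=C(Nc1cnn(-c2ccccc2)c1)c1cccc(NS(=O)(=O)c2ccc(Cl)cc2)c1` differs from compound 1 by chloro in place of hydrogen on an aromatic carbon, and in this assay compound 3 gives 8540 nM, a step of a 1.2-fold lower number from compound 1 to compound 3 (0.07 log units; within the scatter). Within the data shown here, no step is computed between compound 2 and compound 3; their two values alone show how close the three numbers sit.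

Compound 4 `Cc1ccc(-n2cc(NC(=O)c3cccc(NS(=O)(=O)c4ccc(Cl)cc4)c3)cn2)cc1` has not been measured. It differs from compound 3 by methyl in place of hydrogen on an aromatic carbon. Among the measured compounds shown here, this is the same change as the one from compound 1 to compound 2: the place reads identically in both cases, on an aromatic carbon of a six-membered aromatic ring of carbon only, para to a large group, so it is taken as the same change, now made on a core that already carries the chloro described under (chloro in place of hydrogen on an aromatic carbon). For the measured compounds named here, the only precedent for the change is a 1.7-fold lower number from compound 1 to compound 2 (0.22 log units; within the scatter), a step that lies within the scatter. Going by the values given here, the step expected from compound 3 to compound 4 in this assay is a 1.6-fold lower number from compound 3 to compound 4 (0.19 log units; within the scatter), and it rests on that single precedent because a 1.7-fold lower number from compound 1 to compound 2 (0.22 log units; within the scatter) is the one measured instance of this change. Compound 4 is accordingly estimated at 5500 nM, with a likely range from 2500 nM to 12000 nM.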

Compound 4, half-maximal inhibitory concentration: 2440 nM
The estimate for compound 4 lay 2.3-fold (0.35 log units) above the measured number; the whole stated range lies above it.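

In this assay, methyl in place of hydrogen on an aromatic carbon, made on the core that already carries the chloro, gives a 3.5-fold lower number from compound 3 to compound 4 (0.54 log units; beyond the scatter), and this step does not differ from the earlier one beyond what two such steps can scatter: the same change on two cores in this assay, a 1.7-fold lower number (0.22 log units; within the scatter) from compound 1 to compound 2 and a 3.5-fold lower number (0.54 log units; beyond the scatter) from compound 3 to compound 4, 2.1-fold (0.32 log units) apart, within the scatter of two such steps. The chloro, added to the core that already carries the methyl, gives a 2.5-fold lower number from compound 2 to compound 4 (0.39 log units; beyond the scatter), and the same reading holds: the same change on two cores in this assay, a 1.2-fold lower number (0.07 log units; within the scatter) from compound 1 to compound 3 and a 2.5-fold lower number (0.39 log units; beyond the scatter) from compound 2 to compound 4, 2.1-fold (0.32 log units) apart, within the scatter of two such steps. Each change therefore carries from one core to the other as far as these four compounds can resolve, although each comparison rests on a single pair of steps, so this does not establish that the two changes simply add up, nor that either one gains more on the second core.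

The compounds shown leave open whether this reading extends to other groups at the same places, such as a methoxy group, a fluoro group or a carboxylic acid in place of the methyl or the chloro. They also leave open what a longer chain, such as propyl, would do in place of the methyl on the 4-methylphenyl group.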